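Trading Thiophen-2-yl for Iodo on Compound 1

A few compounds are considered here, and "the series" means these few. Any claim that something is new, unique, unknown or untested is made for them only; others in the source may bear on it.

Among the compounds with values here, compound 1 `COc1ncnc2c1c(-c1cccs1)cn2[C@@H]1O[C@H](CO)[C@@H](O)[C@H]1O` is measured in a functional assay on HL-60 cells (Homo sapiens) for antiproliferative activity, read by XTT assay, with a stated time of 72 h (a lower number here means a stronger inhibitor, a higher number a weaker inhibitor), at 80 nM, the lowest of the two numbers known here. Within the data shown here, its only neighbour, compound 2 `Cc1ncnc2c1c(-c1cccs1)cn2[C@@H]1O[C@H](CO)[C@@H](O)[C@H]1O`, gives 5730 nM in this assay, a step of a 72-fold higher number from compound 1 to compound 2 (1.86 log units; beyond the scatter) through methyl in place of methoxy on an aromatic carbon. Compound 3 `COc1ncnc2c1c(I)cn2[C@@H]1O[C@H](CO)[C@@H](O)[C@H]1O` differs from compound 1 at another site: iodo in place of thiophen-2-yl on an aromatic carbon. Among the measured compounds shown here, no measured step touches that site, so the size and direction of the change in this assay are open. For compound 3 a moderate weakening is expected, a 5.0-fold higher number from compound 1 to compound 3 (0.70 log units; beyond the scatter), giving an estimate of 400 nM within a range from 50 nM to 3000 nM.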

Compound 3, half-maximal inhibitory concentration: 2300 nM
Compound 3: the middle estimate sits 5.8-fold (0.76 log units) below what was measured; the range from low to high includes it.
By their numbers in this assay, from the lowest: compound 1; then compound 3; then compound 2.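

In this assay, iodo in place of thiophen-2-yl brings a 29-fold higher number from compound 1 to compound 3 (1.46 log units; beyond the scatter), a large step. This shows that the site carrying the five-membered aromatic ring also strongly affects activity, not only the site of the methoxy group. Nothing measured here gives a reason for this loss.

The compounds shown leave open how a phenyl, a furan-2-yl or an amino group at this position would compare with thiophen-2-yl. They also leave open whether the whole ring or its sulfur is what counts.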